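This account rests on a few compounds, and the source may have more. Where it says the series, first, only, none or still open, it means among the compounds named here.

The measured compounds:

- compound 1, `CN1CCc2c(sc(NC(=O)c3ccc(Cl)cc3)c2C(N)=O)C1`: 38.5%
- compound 2, `CN1CCc2c(sc(NC(=O)c3ccc(Oc4ccccc4)cc3)c2C(N)=O)C1`: 58.9%
- compound 3, `NC(=O)c1c(NC(=O)c2ccc(OCc3ccccc3)cc2)sc2c1CCN(C(=O)c1ccccc1)C2`: 13.7%

All three were tested in an ADME assay on RAW264.7 cells (Mus musculus) for cytotoxicity, read by MTT assay, with a stated time of 48 h, tested at 50 uM; a lower number here means less inhibition, a higher number more inhibition at the concentration tested (going by the name of the read-out). Among these numbers compound 3 stands lowest: its gap to compound 1 is beyond the scatter, and its gap to compound 2 is larger still. Among the measured compounds shown here, the one step between single-change neighbours, a number 20.4 percentage points higher from compound 1 to compound 2 (beyond the scatter), concerns a group on the aromatic ring of the amide side chain and not the ring amine nitrogen, so it does not bear directly on the change considered here.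

Compound 4, `CN1CCc2c(sc(NC(=O)c3ccc(OCc4ccccc4)cc3)c2C(N)=O)C1`, is unmeasured. It differs from compound 3 in one place: methyl in place of benzoyl on an amine nitrogen in a ring. After this change compound 4 carries the same methyl-bearing ring nitrogen as compounds 1 and 2, both of which gave clearly higher numbers than compound 3 in this assay. For the measured compounds named here, no measured step exists for this exact change, so the expectation rests on that resemblance alone. Compound 4 is therefore expected to rise, with a number 31.3 percentage points higher from compound 3 to compound 4 (beyond the scatter) as the estimated step, into the region between compounds 1 and 2. The estimate for compound 4 is 45%, with a range from 25% to 65%.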

Compound 4, a percentage reported as inhibition, at one concentration (the size of the read-out at that concentration, not a potency): 37.6%
The estimate for compound 4 lay 7.4 percentage points above the measured number; the range from low to high includes it.
By their numbers in this assay, from the lowest: compound 3; then compounds 4 and 1 (each within the scatter of the next); then compound 2.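

In this assay the amine nitrogen in the ring now has a measured step of its own: with the benzyloxy side chain held fixed, methyl in place of benzoyl gives a number 23.9 percentage points higher from compound 3 to compound 4 (beyond the scatter) and so shows that the group on this nitrogen alone can move the number. With methyl on that nitrogen, the side chain gives a less simple picture than the earlier step from chloro to phenoxy suggested: benzyl in place of phenyl on the oxygen gives a number 21.3 percentage points lower from compound 2 to compound 4 (beyond the scatter) while benzyloxy in place of chloro gives a number 0.9 percentage points lower from compound 1 to compound 4 (within the scatter) and leaves compound 1 and compound 4 indistinguishable here, so a larger side chain does not by itself go with a higher number. No measured evidence is available to explain any of these steps.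

The compounds shown leave open whether the step on the nitrogen follows the aromatic ring of benzoyl or its carbonyl, which an acetyl or a benzyl group there would help to separate. Also open, on these data alone, is whether the step has the same size with chloro or phenoxy on the aromatic carbon, since benzoyl appears here only with benzyloxy.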